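Removing the hydroxyethylamino arm from a fused diamine core

The source may hold more compounds than are shown below. What is called first, only, known or untested is meant among the compounds shown, and "the series" means these compounds.

Three compounds have been measured in a functional assay on A-431 cells (Homo sapiens) for inhibition, read by sulforhodamine B assay, with a stated time of 2 days; on this read-out higher numbers stand for weaker inhibition of growth and lower numbers for stronger inhibition of growth:

compound 1 `N#Cc1cc2c(N)nc(NCCO)nc2nc1NCCO`, giving 6250 nM
compound 2 `Cc1c(C#N)c(Nc2ccc(S(N)(=O)=O)cc2)nc2ncnc(N)c12`, giving 2940 nM
compound 3 `Cc1c(C#N)c(Nc2ccc(S(N)(=O)=O)cc2)nc2nc(NCCO)nc(N)c12`, giving only a limit, > 100000 nM

Compound 3 and compound 2 differ by one change, (hydrogen in place of (2-hydroxyethyl)amino on an aromatic carbon), and that change brings an at least 34-fold lower number from compound 3 to compound 2 (1.53 log units; beyond the scatter). The same change separates compound 1 from compound 4 `N#Cc1cc2c(N)ncnc2nc1NCCO`, which is hydrogen in place of (2-hydroxyethyl)amino on an aromatic carbon, with the place around it the same in both pairs. How the cores of compound 1 and compound 3 differ is not broken down here. Compound 1 stands higher than compound 2 in this assay, beyond the scatter. Since the measured step starts from a limit, its true size is not known; still, a lower number is expected, and compound 4 is estimated to give a 10-fold lower number from compound 1 to compound 4 (1.02 log units; beyond the scatter). Compound 4 is therefore estimated at 600 nM, within 100 nM to 3000 nM.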

Compound 4, concentration for 50% growth inhibition: 26600 nM
Beside the measured number, compound 4's estimate is 44-fold (1.65 log units) below it, outside the stated range (above it).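

In this assay, hydrogen in place of (2-hydroxyethyl)amino brings a 4.3-fold higher number from compound 1 to compound 4 (0.63 log units; beyond the scatter). Set beside the earlier step, the change does not carry over from one core to the other, even in direction: the same change on two cores in this assay, an at least 34-fold lower number (1.53 log units; beyond the scatter) from compound 3 to compound 2 and a 4.3-fold higher number (0.63 log units; beyond the scatter) from compound 1 to compound 4, at least 140-fold (2.16 log units) apart, beyond the scatter of two such steps Compound 3 gives > 100000 nM, which is a limit and not a number, so the size of that step stays unknown, and two pairs do not show which difference between the cores decides the direction.

As far as these compounds go, it remains open whether a longer chain, such as (3-hydroxypropyl)amino, or a methylamino group in the same place would follow the core of compound 1 or that of compound 3. From the compounds shown here alone, it also remains open which way the change would run on a core carrying only the methyl group or only the sulfonamide-bearing aniline.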